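The compounds below may be only part of what the source reports. "The series", "measured", "known", "first", "only" and "open" are said of these compounds alone.

Of the compounds shown here, three sharing one core have been tested in a functional assay on A-431 cells (Homo sapiens) for cytotoxicity (a higher number here means that more compound is needed for the effect, a lower number that less compound is needed), and they differ only in the substituted phenyl group on the chain. Compound 1 `COC1=C(C)C(=O)/C(=C(O)/C=C/c2ccc(OC)cc2)C(=O)C1(C)C`, with 4-methoxyphenyl, gives 9.2 ug/mL. Compound 2 `COC1=C(C)C(=O)/C(=C(O)/C=C/c2ccccc2OC)C(=O)C1(C)C`, with 2-methoxyphenyl, gives 6.6 ug/mL. Compound 3 `COC1=C(C)C(=O)/C(=C(O)/C=C/c2ccc(F)cc2)C(=O)C1(C)C`, with 4-fluorophenyl, gives 4.1 ug/mL. Among the compounds with values here, on these numbers, compound 3 stands clear of only one neighbour: the data show a 2.2-fold lower number from compound 1 to compound 3 (0.35 log units; beyond the scatter), a modest step, but also a 1.6-fold lower number from compound 2 to compound 3 (0.21 log units; within the scatter).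

Compound 4 `COC1=C(C)C(=O)/C(=C(O)/C=C/c2ccc(C)cc2)C(=O)C1(C)C` has methyl in place of fluoro on an aromatic carbon, para to a large group (methyl in place of fluoro on an aromatic carbon). Within the data shown here, no tested compound carries this methyl, so any forecast rests on thin evidence. The nearest guide is the exchange at this same place, where fluoro replaced methoxy and the data show a 2.2-fold lower number from compound 1 to compound 3 (0.35 log units; beyond the scatter). Compound 3 would therefore be a fair starting point, with the number expected to drift back towards the values of the two methoxy compounds rather than fall further. The expected change is a 1.5-fold higher number from compound 3 to compound 4 (0.17 log units; within the scatter), which would be no real step beyond the scatter. For compound 4, the estimated value in this assay is 6 ug/mL. The estimated range for compound 4 runs from 3 ug/mL to 12 ug/mL.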

Compound 4, concentration for half-maximal effect: 5.1 ug/mL
The estimate for compound 4 lay 1.2-fold (0.07 log units) above the measured number, within the range that was stated.
By their numbers in this assay, from the lowest: compounds 3, 4, 2 and 1 (each within the scatter of the next, the first and the last beyond it).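

In this assay, within the data shown here, putting methyl in place of fluoro on an aromatic carbon, para to a large group, gives no step that can be told from the scatter (a 1.2-fold higher number from compound 3 to compound 4 (0.09 log units; within the scatter)). Among these compounds, this is new information about the position: the earlier compounds showed only that fluoro could be separated from a methoxy group, whereas here two groups of one heavy atom each cannot be separated from one another. Methyl also cannot be separated from either methoxy compound (a 1.3-fold lower number from compound 2 to compound 4 (0.11 log units; within the scatter); a 1.8-fold lower number from compound 1 to compound 4 (0.26 log units; within the scatter)), so the only step beyond the scatter remains the modest one between the 4-methoxyphenyl and 4-fluorophenyl compounds (a 2.2-fold lower number from compound 1 to compound 3 (0.35 log units; beyond the scatter)), and it gives no clear order for the 4-methylphenyl group.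

The compounds shown leave open whether a quite different group at this place, such as an amine, a carboxylic acid or a longer chain, would move the number clearly beyond the scatter. Nothing measured alongside these cytotoxicity numbers accounts for the small differences among them.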